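The source may report more compounds than this note shows. Statements on the series, on what has been measured and on what is new or still open speak of the compounds shown alone.

The measured compounds in a functional assay on DU-145 cells (Homo sapiens) for inhibition, read by trypan blue exclusion, with a stated time of 96 h; a higher number here means a weaker inhibitor of growth, a lower number a stronger inhibitor of growth:
Compound 1 `CN(C)c1ccc(/C=C(/SCc2ccc(Cl)cc2Cl)C(=O)c2ccc(Cl)cc2)cc1` gives 50000 nM.
Compound 2 `O=C(/C(=C\c1ccc(O)cc1)SCc1ccc(Cl)cc1)c1ccc(Br)cc1` gives 10000 nM.
Compound 3 `COc1ccc(/C=C(/Sc2ccc(C)cc2)C(=O)c2ccc(Cl)cc2)cc1O` gives 1000 nM.

Among these three numbers compound 2 stands second highest: compound 1 sits at a higher number, beyond the scatter, and compound 3 at a lower number, also beyond the scatter. The unmeasured compound 4 `COc1ccc(/C=C(/SCc2ccc(Cl)cc2)C(=O)c2ccc(Br)cc2)cc1` differs from compound 2 in one place: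

methyl in place of hydrogen on an oxygen on an aromatic ring

No measured pair isolates this change, so its size is not shown by any comparison here. In this assay the step is expected to be modest, toward a lower number, with a wide range allowed. For compound 4 the estimated value is 5000 nM, expected between 1000 nM and 30000 nM. That amounts to an expected step of a 2.0-fold lower number from compound 2 to compound 4 (0.30 log units; within the scatter).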

Compound 4, concentration for 50% growth inhibition: 10000 nM
Compound 4: middle estimate off by 2.0-fold (0.30 log units), on the low side; low and high end bracket the measured number.
By their numbers in this assay, from the lowest: compound 3; then compounds 2 and 4 (each within the scatter of the next); then compound 1.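

In this assay, among these compounds, the change from hydroxy to methoxy gives no change at the digits printed from compound 2 to compound 4 (within the scatter) and is the first comparison here that isolates a single change. Putting methyl in place of the hydrogen on this oxygen leaves growth inhibition where it was, so the hydrogen is not required for the level of activity seen with compound 2.

Going by these compounds, whether an ethyl group or a longer chain on this oxygen, or an amine in place of the hydroxy, would be tolerated as well remains open. No measurement here offers a reason for this flat result.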